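The compounds below may be only part of what the source reports. "The series", "measured", "known", "first", "only" and "open" are said of these compounds alone.

Measured compounds: compound 1 `Cc1ccc(C(=O)N[C@@H]2C[C@H](C)CC[C@H]2C(C)C)cc1` gives 5.4% in a functional assay on HEK293 cells for agonist activity at transient receptor potential cation channel subfamily V member 1 (Homo sapiens); on this read-out higher numbers stand for larger maximal responses and lower numbers for smaller maximal responses; compound 2 `CC(C)[C@@H]1CC[C@@H](C)C[C@H]1NC(=O)c1ccc(-c2ccccc2)cc1` gives 7.8%; compound 3 `CC(C)[C@@H]1CC[C@@H](C)C[C@H]1NC(=O)c1cccc(Cl)c1` gives 41.9%.

Compound 2 stands second highest of the three, close to compound 1 and far below compound 3. Compound 4 `CC(C)[C@@H]1CC[C@@H](C)C[C@H]1NC(=O)c1ccc(Cl)cc1` arises from compound 2 by the change (chloro in place of phenyl on an aromatic carbon), on an aromatic carbon para to a large group. Going by the values given here, the only step at that position, a number 2.4 percentage points higher from compound 1 to compound 2 (within the scatter), lies within the scatter, and no measured step covers chloro entering here. Compound 3 carries chloro elsewhere on the ring and gives 41.9%; compound 2 gives 7.8%. The step to compound 4 is therefore expected small, with the direction open, a number 4.2 percentage points higher from compound 2 to compound 4 (within the scatter). Compound 4 is estimated at 12%, between 3% and 35%.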

Compound 4, largest response reached (reported as efficacy), in percent of the reference or control that the assay uses: 53.8%
Beside the measured number, compound 4's estimate is 41.8 percentage points below it; measured number above the stated range.
By their numbers in this assay, from the lowest: compounds 1 and 2 (each within the scatter of the next); then compound 3; then compound 4.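

In this assay, the aromatic carbon para to a large group proves sensitive to the group it carries: chloro in place of phenyl gives a number 46 percentage points higher from compound 2 to compound 4 (beyond the scatter), and chloro in place of methyl gives a number 48.4 percentage points higher from compound 1 to compound 4 (beyond the scatter). Methyl and phenyl at this carbon stay within the scatter of each other, so the earlier compounds gave no sign of this sensitivity. Nothing available explains the rise with chloro.

Open, on these data alone, is whether bromo, fluoro or an amine at this carbon would reach the response seen with chloro.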